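Removing the Ester From Compound 1: Expected Cytotoxicity

This account rests on a few compounds, and the source may have more. Where it says the series, first, only, none or still open, it means among the compounds named here.

Within the data shown here, compound 1 `COC(=O)c1ccc(NCc2cncn2Cc2ccc(Cl)cc2)cc1-c1ccccc1` is the only compound with a number here: in a toxicity assay on NIH3T3 cells (Mus musculus) for cytotoxicity, read by resazurin assay (a lower number here means that less compound is needed, a higher number that more compound is needed for the effect), compound 1 gives 25000 nM. Compound 2 `COC(=O)c1ccc(NCc2cncn2Cc2ccc(OC)cc2)cc1-c1ccccc1`, its close relative bearing a methoxy group in place of the chloro group, has no result; in this assay compound 2 gives "not determined" (no result reported). Compound 3 `Clc1ccc(Cn2cncc2CNc2cccc(-c3ccccc3)c2)cc1` has not been tested yet. It differs from compound 1 by hydrogen in place of methoxycarbonyl on an aromatic carbon, with the place being the aromatic carbon para to a large group and ortho to the phenyl group. Among the measured compounds shown here, no step between two measured compounds is available to guide the expectation, so the size of the change in this assay must be guessed. With the ester gone, the expected step from compound 1 to compound 3 in this assay is a 1.2-fold higher number from compound 1 to compound 3 (0.08 log units; within the scatter), a change of little more than the usual scatter. For compound 3 in this assay the expected value is 30000 nM, within a range from 10000 nM to 90000 nM.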

Compound 3, half-maximal effective concentration: 10000 nM
The estimate for compound 3 lay 3.0-fold (0.48 log units) above the measured number; the range from low to high includes it.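

In this assay, replacing the methoxycarbonyl group with hydrogen on this aromatic carbon gives a 2.5-fold lower number from compound 1 to compound 3 (0.40 log units; beyond the scatter), meaning that less compound is needed for the effect once the ester is gone. This is the only measured step shown, and it gives the first sign that this position matters for the read-out: the change is modest, but it lies beyond the usual scatter. Nothing available explains why the number moves in this direction.

On these data alone, with only hydrogen and methoxycarbonyl compared, it remains open whether other groups on this carbon would shift the number in the same way. A carboxylic acid or an amine at this place would help show whether the step belongs to the ester specifically or to having any group there at all.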